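A cyclopropyl step from a compound at the limit

The compounds below may be only part of what the source reports. "The series", "measured", "known", "first", "only" and "open" are said of these compounds alone.

Measured in a functional assay on MCF7 cells (Homo sapiens) for antiproliferative activity, read by MTT assay, with a stated time of 72 h; a lower number here means a stronger inhibitor, a higher number a weaker inhibitor:
Compound 1 `COc1ncc(-c2ccc3c(c2)NC(=O)CO3)cc1NS(=O)(=O)c1ccc(F)cc1`: 32300 nM
Compound 2 `COc1ncc(-c2ccc3c(c2)N(C2CCCCC2)C(=O)CO3)cc1NS(=O)(=O)c1ccc(F)cc1`: 30100 nM
Compound 3 `O=C1COc2ccc(-c3cnc(Cl)c(NS(=O)(=O)c4ccc(F)cc4)c3)cc2N1`: > 40000 nM

The entry for compound 3 at > 40000 nM is a limit of the assay and not a number. Compound 4 `O=C1COc2ccc(-c3cnc(Cl)c(NS(=O)(=O)c4ccc(F)cc4)c3)cc2N1C1CC1` carries cyclopropyl in place of hydrogen on an amide-type nitrogen in a ring. For the measured compounds named here, the one measured step of this kind, with cyclohexyl in place of that hydrogen, was a 1.1-fold lower number from compound 1 to compound 2 (0.03 log units; within the scatter). The measured step to the chloro compound, an at least 1.2-fold higher number from compound 1 to compound 3 (0.09 log units; that floor lies within the scatter), gives only a floor. No step beyond the scatter is therefore expected in this assay. The estimated step is a number no higher from compound 3 to compound 4 (the limit leaves the size open). Compound 4 is expected at 40000 nM, with an estimated range from 25000 nM to 60000 nM.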

Compound 4, half-maximal inhibitory concentration: 16700 nM
For compound 4 the middle estimate is 2.4-fold (0.38 log units) above the measured one, outside the stated range (below it).
By their numbers in this assay, from the lowest: compounds 4, 2 and 1 (each within the scatter of the next). At a limit, above all of these: compound 3.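

In this assay, a change on the amide-type nitrogen in the ring now gives a step beyond the scatter (an at least 2.3-fold lower number from compound 3 to compound 4 (0.37 log units; beyond the scatter)). The earlier change at this nitrogen, cyclohexyl on the methoxy compound, stayed within the scatter (a 1.1-fold lower number from compound 1 to compound 2 (0.03 log units; within the scatter)). Compound 3 gives a limit of the assay, so this step is only a floor: (the limit of > 40000 nM in this assay, at which 1 of the 4 values shown sits).

As far as these compounds go, it remains open whether cyclopropyl would do the same on compound 1, which carries methoxy in place of chloro. Also open, from the compounds shown here alone, is how a longer chain or an amine on this nitrogen would read.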